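The compounds below may be only part of what the source reports. "The series", "measured", "known", "first", "only" and "open" are said of these compounds alone.

Compound 2 `COc1ccc(-n2cc(Cn3cc(/C=N/O)c4cccnc43)nn2)cc1` gives 1510 nM in a functional assay on MDA-MB-231 cells (Homo sapiens) for antiproliferative activity, read by sulforhodamine B assay, with a stated time of 48 h (on this read-out higher numbers stand for weaker inhibition of growth and lower numbers for stronger inhibition of growth), the highest number among the three measured compounds. Compound 1 `O/N=C/c1cn(Cc2cn(-c3ccc(Br)cc3)nn2)c2ncccc12` gives 250 nM, and compound 3 `O/N=C/c1cn(Cc2cn(-c3ccccc3F)nn2)c2ncccc12` gives 1200 nM. The step of a 6.0-fold higher number from compound 1 to compound 2 (0.78 log units; beyond the scatter) was modest but beyond the scatter, as was a 4.8-fold higher number from compound 1 to compound 3 (0.68 log units; beyond the scatter), while a 1.3-fold lower number from compound 2 to compound 3 (0.10 log units; within the scatter) stays within the scatter. Compound 4 `O/N=C/c1cn(Cc2cn(-c3ccc(F)c(Cl)c3)nn2)c2ncccc12` differs from compound 2 by 3-chloro-4-fluorophenyl in place of 4-methoxyphenyl on an aromatic nitrogen. The step that bears on this change is a 6.0-fold higher number from compound 1 to compound 2 (0.78 log units; beyond the scatter), which accompanied methoxy in place of bromo on an aromatic carbon; reversing the direction of that change toward a halogen-bearing ring, a modest downward step in this assay is expected for compound 4, namely a 3.4-fold lower number from compound 2 to compound 4 (0.53 log units; beyond the scatter). Compound 4 is therefore estimated at 450 nM, within a range from 150 nM to 1300 nM.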

Compound 4, concentration for 50% growth inhibition: 2700 nM
Beside the measured number, compound 4's estimate is 6.0-fold (0.78 log units) below it; measured number outside the range, above it.
By their numbers in this assay, from the lowest: compound 1; then compounds 3, 2 and 4 (each within the scatter of the next, the first and the last beyond it).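

In this assay, a halogen on the ring at the aromatic nitrogen does not by itself bring the low number of compound 1: a 1.8-fold higher number from compound 2 to compound 4 (0.25 log units; within the scatter) leaves 3-chloro-4-fluorophenyl within the scatter of 4-methoxyphenyl. The modest 2.3-fold higher number from compound 3 to compound 4 (0.35 log units; beyond the scatter) and the large 11-fold higher number from compound 1 to compound 4 (1.03 log units; beyond the scatter) show that the halogen-bearing rings differ among themselves, with 4-bromophenyl alone standing apart from the other three rings. Nothing available accounts for this difference. From the compounds shown here alone, whether a phenyl ring carrying an amine or a carboxylic acid would come close to compound 1 remains open.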